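The compounds below may be only part of what the source reports. "The series", "measured", "known", "first", "only" and "open" are said of these compounds alone.

Of the compounds shown here, three have been tested in a functional assay on PC-3 cells (Homo sapiens) for inhibition, read by sulforhodamine B assay, with a stated time of 48 h, tested at 100 uM (a lower number here means less inhibition of growth, a higher number more inhibition of growth at the concentration tested), and they spread over a fair span. Compound 1 `Cc1ccc2occ(C3N=C(c4ccccc4)SS3)c(=O)c2c1` gives 40%. Compound 2 `O=c1c(C(=S)Nc2ccccc2)coc2cc(Cl)ccc12` gives 55% in this assay, which puts it second highest of the three numbers: it sits above compound 1 by a margin beyond the scatter and below compound 3 by a margin of the same size, also beyond the scatter. Compound 3 `O=c1c(C2N=C(c3ccccc3)SS2)coc2cc(Cl)c(Cl)cc12` gives 70% in this assay, the highest number of the set.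

The step under consideration leads from compound 2 to compound 4 `O=c1c(C(=S)Nc2ccccc2)coc2cc(Cl)c(Cl)cc12`, which has not yet been measured in this assay. The change is chloro in place of hydrogen on an aromatic carbon. Compound 4 therefore carries the same pair of chloro groups on its fused carbon ring as compound 3, while keeping the thioamide side of compound 2. Within the data shown here, no pair of measured compounds differs in exactly this way, so the size of the step has to be judged from the numbers at hand. Among the measured compounds shown here, because compound 3, the one measured compound with this chloro pattern, gives 70%, a rise from compound 2 is expected rather than a fall, of a size somewhat beyond the scatter. The step from compound 2 to compound 4 is thus estimated at a number 7 percentage points higher from compound 2 to compound 4 (within the scatter). For compound 4 in this assay a value of 62% is expected, within a range of 48% to 76%.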

Compound 4, percent growth inhibition at one concentration: 16%
Compound 4: middle estimate off by 46 percentage points, on the high side; measured number outside the range, below it.
By their numbers in this assay, from the lowest: compound 4; then compound 1; then compound 2; then compound 3.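

In this assay, chloro in place of hydrogen on this aromatic carbon of the six-membered ring, ortho to a chloro group, gives a number 39 percentage points lower from compound 2 to compound 4 (beyond the scatter), so on the thioamide side this position is far from indifferent to the change, and the rise that compound 3 seemed to suggest does not appear. The chloro pair alone therefore does not set the level of growth inhibition: with the same pair on the core, compound 3 gives 70% and compound 4 gives 16%, so the outcome depends on the group attached to the core in each compound. Nothing measured here accounts for the fall in the number from the added chloro group.

Compounds with hydrogen and chloro are the only ones shown at this aromatic carbon with the thioamide side, so it remains open whether a fluoro, methyl or methoxy group there would go with a similar fall or whether the drop is particular to chloro. From the compounds shown here alone, it also remains open whether the fall would persist with an amine or a carboxylic acid on the phenyl ring of the thioamide side.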